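Swapping chloro for trifluoromethyl on the fused ring

This account rests on a few compounds, and the source may have more. Where it says the series, first, only, none or still open, it means among the compounds named here.

Measured so far:
compound 1 `CC(C(=O)O)c1nn(Cc2cn3cc(OCC4CC4)c(Cl)cc3n2)c2ccccc2c1=O`: 6 nM
compound 2 `COC(C(=O)O)c1nn(Cc2cn3cc(OCC4CC4)c(Cl)cc3n2)c2ccccc2c1=O`: 23 nM
compound 3 `CC(C)(C(=O)O)c1nn(Cc2cn3cc(OCC4CC4)c(Cl)cc3n2)c2ccccc2c1=O`: 7.7 nM

In a functional assay on CHO cells for antagonist activity at sphingosine 1-phosphate receptor 2 (Homo sapiens), read by calcium flux (a lower number here means a stronger inhibitor, a higher number a weaker inhibitor), compound 1 gives the lowest of the three numbers. Its neighbour is compound 3, a 1.3-fold higher number from compound 1 to compound 3 (0.11 log units; within the scatter), while compound 2 lies further off, a 3.8-fold higher number from compound 1 to compound 2 (0.58 log units; beyond the scatter). Both of those steps change the carboxy-bearing side chain; none touches the fused ring.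

Compound 4 `CC(C(=O)O)c1nn(Cc2cn3cc(OCC4CC4)c(C(F)(F)F)cc3n2)c2ccccc2c1=O` differs from compound 1 by trifluoromethyl in place of chloro on an aromatic carbon. Within the data shown here, no measured step bears on this position, so the expectation rests on the fact that this part of the shared core is otherwise untouched. Compound 4 is expected to show a 1.3-fold higher number from compound 1 to compound 4 (0.12 log units; within the scatter), a step not beyond the scatter, estimated at 8 nM with a range from 3 nM to 25 nM.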

Compound 4, half-maximal inhibitory concentration: 3.4 nM
Compound 4: middle estimate off by 2.4-fold (0.37 log units), on the high side, within the range that was stated.
By their numbers in this assay, from the lowest: compounds 4, 1 and 3 (each within the scatter of the next, the first and the last beyond it); then compound 2.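

Among these compounds, this is the first reading at the position opposite the ring nitrogen, which none of the side-chain steps touched. In this assay, trifluoromethyl in place of chloro gives a 1.8-fold lower number from compound 1 to compound 4 (0.25 log units; within the scatter), so four heavy atoms can stand where one stood without a change that clears the scatter. No measurement here accounts for how the two groups compare.

From the compounds shown here alone, how a nitrile or a plain hydrogen would fare at this position stays open. So does whether trifluoromethyl behaves the same way alongside the 1-carboxy-1-methylethyl side chain of compound 3.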